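Chloro added to the phenyl of a sulfamate furanamide

The compounds below may be only part of what the source reports. "The series", "measured", "known", "first", "only" and "open" are said of these compounds alone.

Among the compounds with values here, compound 1 `Cc1ccccc1N(C)C(=O)c1ccc(-c2ccc(OS(N)(=O)=O)cc2)o1` is the only member of this set with a number: in an assay on cytosol from placenta for inhibition of 17-beta-hydroxysteroid dehydrogenase type 1 (Homo sapiens), read by HPLC, with a stated time of 10 min, tested at 1 uM, in the presence of a further agent that is not named here (a lower number here means less inhibition, a higher number more inhibition at the concentration tested (going by the name of the read-out)), compound 1 gives 15%. Compound 2 `Cc1cc(-c2ccc(C(=O)N(C)c3ccccc3C)o2)ccc1OS(N)(=O)=O` carries a methyl on the sulfamate-bearing ring, but for compound 2 this assay shows "nd" (no result reported), so nothing can be read from it. Compound 3 `Cc1ccccc1N(C)C(=O)c1ccc(-c2ccc(OS(N)(=O)=O)cc2Cl)o1` is not yet measured; it differs from compound 1 by chloro in place of hydrogen on an aromatic carbon. Within the data shown here, no step between measured compounds exists, so only a small shift in this assay is expected, likely within the scatter, at a number 5 percentage points higher from compound 1 to compound 3 (within the scatter). Compound 3 is estimated at 20%, within 5% to 45%.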

Compound 3, a percentage reported as inhibition, at one concentration (the size of the read-out at that concentration, not a potency): 13%
Estimate against measurement, compound 3: 7 percentage points above; measured number inside the range.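

Chloro on the aromatic carbon ortho to a large group and meta to a sulfamoyloxy group gives a number 2 percentage points lower from compound 1 to compound 3 (within the scatter) in this assay and is the first readable step in the series, with this position accepting chloro without a shift beyond the scatter. The reading comes from one concentration, so it gives no potency. No measurement offered here bears on this result.

On these data alone, whether an amine or a methoxy group at this position would read differently remains open. So does the effect of chloro on the other carbons of this ring.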